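A few compounds are considered here, and "the series" means these few. Any claim that something is new, unique, unknown or untested is made for them only; others in the source may bear on it.

Compounds measured so far:
Compound 1 `COC(=O)c1ccc(NC2=CC(=O)c3ncncc3C2=O)cc1`: 5800 nM
Compound 2 `CC(=O)c1cccc(NC2=CC(=O)c3ncncc3C2=O)c1`: 5200 nM
Compound 3 `COc1cccc(NC2=CC(=O)c3ncncc3C2=O)c1`: 1800 nM

In a functional assay on BXPC-3 cells (Homo sapiens) for cytotoxicity, read by MTT assay, with a stated time of 72 h (on this read-out lower numbers stand for stronger inhibition and higher numbers for weaker inhibition), compound 1 gives 5800 nM, the highest of the three numbers. Compound 2 at 5200 nM lies within the scatter of compound 1, so no order between them can be read. Compound 3 at 1800 nM stands furthest from compound 1, beyond the scatter. Among the measured compounds shown here, the only single-point step available is a 2.9-fold lower number from compound 2 to compound 3 (0.46 log units; beyond the scatter).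

Compound 4 `O=C1C(Nc2ccc(CO)cc2)=CC(=O)c2ncncc21` has not yet been measured. It differs from compound 1 by hydroxymethyl in place of methoxycarbonyl on an aromatic carbon. The step from compound 2 to compound 3 exchanges one small carbon-oxygen substituent for another on the same shared core, and it is the nearest guide; it does not concern the same two groups nor the same position, so the guidance is loose. On that basis a modest move toward lower numbers in this assay is expected for compound 4, of about a 1.9-fold lower number from compound 1 to compound 4 (0.29 log units; within the scatter), and compound 4 is estimated at 3000 nM, within a range of 1200 nM to 8000 nM.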

Compound 4, half-maximal inhibitory concentration: 5700 nM
For compound 4 the middle estimate is 1.9-fold (0.28 log units) below the measured one; the range from low to high includes it.
By their numbers in this assay, from the lowest: compound 3; then compounds 2, 4 and 1 (each within the scatter of the next).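

Exchanging methoxycarbonyl for hydroxymethyl on an aromatic carbon, para to a large group, gives in this assay a 1.0-fold lower number from compound 1 to compound 4 (0.01 log units; within the scatter) and so no readable difference. The earlier compounds shown here offered no single-place change at this position; here a group of 4 heavy atoms with 0 hydrogen-bond donors and one of 2 heavy atoms with 1 hydrogen-bond donor cannot be told apart on this read-out. Nothing measured on these compounds bears on why the two groups read alike.

From the compounds shown here alone, whether an amine, a carboxylic acid or a longer chain carrying a terminal hydroxyl would also read alike at this position remains open. Going by these compounds, it is also open whether hydroxymethyl would give the same reading on another carbon of the same ring.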